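Little Tolerance Shift Expected at Compound 4

The compounds below may be only part of what the source reports. "The series", "measured", "known", "first", "only" and "open" are said of these compounds alone.

Values in an ADME assay on BHK cells (Mesocricetus auratus) for cytotoxicity, read by MTT assay; a higher number here means that more compound is tolerated, a lower number that less compound is tolerated
- Compound 1 `OC[C@@H]1[C@@H](O)[C@H](O)[C@@H](O)CN1CCCCCCOc1ccc(OC(F)(F)F)cc1` gives > 500000 nM, a limit of the assay
- Compound 2 `OC[C@@H]1[C@@H](O)[C@H](O)[C@@H](O)CN1CC/C=C\CCOc1cc(F)ccc1F` gives > 500000 nM, a limit of the assay
- Compound 3 `CCC1CCC(OCCCCCCN2C[C@H](O)[C@@H](O)[C@H](O)[C@H]2CO)CC1` gives 475000 nM

Compound 3 carries the only actual number among these three, while the other two results are limits, as shown by the limit of > 500000 nM in this assay, at which 2 of the 3 values shown sit. Compound 4 `COc1ccccc1OCCCCCCN1C[C@H](O)[C@@H](O)[C@H](O)[C@H]1CO` differs from compound 3 by 2-methoxyphenyl in place of 4-ethylcyclohexyl on an oxygen on a saturated carbon, with 2-methoxyphenyl in place of 4-ethylcyclohexyl on an oxygen on a saturated carbon. For the measured compounds named here, no measured pair differs in one place, so no measured step guides the expectation. The estimated step of a 1.0-fold higher number from compound 3 to compound 4 (0.00 log units; within the scatter) is expected to stay within the usual scatter, in neither direction. For compound 4 the estimated value in this assay is 480000 nM, with an expected range from 250000 nM to 900000 nM.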

Compound 4, half-maximal cytotoxic concentration: > 500000 nM
Compound 4: only a limit was reported; the forecaster's own chance of this, stated with the estimate: 55%; middle value at least 1.0-fold (0.01 log units) from the limit.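

In this assay, for the compounds shown here, the change of group on the oxygen gives the first step that can be read at this position: an at least 1.0-fold higher number from compound 3 to compound 4 (0.02 log units; that floor lies within the scatter). The aromatic group thus brings no sign of a lower number, though nothing shows a real rise either. The true size of the step stays hidden at the top of the range: the limit of > 500000 nM in this assay, at which 3 of the 4 values shown sit.

The compounds shown leave open how far compound 4 really lies from compound 3. They also leave open whether an amine or a carboxylic acid at this position would bring the number down.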